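Compound 4: One Stereocentre Redrawn

The source may report more compounds than this note shows. Statements on the series, on what has been measured and on what is new or still open speak of the compounds shown alone.

Of the compounds shown here, three have been measured in a physicochemical assay for solubility, read by chemiluminescence, measured as kinetic solubility; on this read-out higher numbers stand for higher solubility and lower numbers for lower solubility. Compound 1 `O=C([C@@H]1CCCN1)N1CCC2(CCN(c3nccc(NCc4ccc(Cl)cc4Cl)n3)CC2)C1` gives 165 ug/mL, compound 2 `O=C([C@H]1CCCN1)N1CCC2(CCN(c3nccc(NCc4ccc(Cl)cc4Cl)n3)CC2)C1` gives 180 ug/mL, and compound 3 `O=C([C@H]1CCCCN1)N1CCC2(CCN(c3nccc(NCc4ccc(Cl)cc4Cl)n3)CC2)C1` gives 172 ug/mL. Compound 3 therefore lies within the scatter of both other compounds, and the numbers set no order among the three.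

The next compound is compound 4 `O=C([C@@H]1CCCCN1)N1CCC2(CCN(c3nccc(NCc4ccc(Cl)cc4Cl)n3)CC2)C1`, whose difference from compound 3 is this: the two compounds have the same atoms and bonds and differ only in configuration as drawn: 1 of 1 stereo elements differ; a stereocentre at a saturated ring carbon is drawn R in compound 3 and S in compound 4. Within the data shown here, the closest precedent is the fact that compounds 1 and 2 differ only in the configuration as drawn, and that change of configuration gave only a 1.1-fold higher number from compound 1 to compound 2 (0.04 log units; within the scatter). The replacement of pyrrolidin-2-yl by piperidin-2-yl on a carbonyl carbon was similarly small, giving a 1.0-fold higher number from compound 1 to compound 3 (0.02 log units; within the scatter) and a 1.0-fold lower number from compound 2 to compound 3 (0.02 log units; within the scatter). Among the measured compounds shown here, with only one such pair of configurations measured, the precedent is thin, but every measured step stays within the scatter. No step beyond the scatter is therefore expected, and the estimated change is no change at the digits printed from compound 3 to compound 4 (within the scatter). For compound 4 the expected value in this assay is 172 ug/mL, with an estimated range from 110 ug/mL to 260 ug/mL.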

Compound 4, solubility: 170 ug/mL
The estimate for compound 4 lay 1.0-fold (0.01 log units) above the measured number, and the stated range covers the measured number.
By their numbers in this assay, from the lowest: compounds 1, 4, 3 and 2 (each within the scatter of the next).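

In this assay, the change of configuration has now been read on the piperidin-2-yl pair as well as the pyrrolidin-2-yl pair, and it gives a 1.0-fold lower number from compound 3 to compound 4 (0.01 log units; within the scatter), so the earlier result no longer rests on a single pair: the fact that compounds 3 and 4 differ only in the configuration as drawn. The change to piperidin-2-yl in place of pyrrolidin-2-yl on a carbonyl carbon can now be read for compound 4 as well, giving a 1.1-fold lower number from compound 2 to compound 4 (0.02 log units; within the scatter) and a 1.0-fold higher number from compound 1 to compound 4 (0.01 log units; within the scatter). All the steps among these four compounds therefore stay within the scatter, whichever of the two rings is present and however the stereocentre is drawn.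

From the compounds shown here alone, it remains open whether the number would hold with an open-chain amine or a carboxylic acid in place of the saturated ring on the carbonyl carbon. Going by these compounds, it is equally open whether the configuration would still make so little difference with such a group.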